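The source may hold more compounds than are shown below. What is called first, only, known or untested is meant among the compounds shown, and "the series" means these compounds.

Compound 3 (`COc1cc(-c2nnc(SCC(=O)c3ccccc3)n2N2C(=O)c3ccccc3C2=O)cc(OC)c1OC`) carries a benzoyl group on the sulfur-bound chain carbon of the shared core. In a functional assay on A549 cells (Homo sapiens) for cytotoxicity, read by MTT assay, with a stated time of 48 h (on this read-out higher numbers stand for weaker inhibition and lower numbers for stronger inhibition), compound 3 gives > 200000 nM, which is a limit of the assay rather than a measured number. Compound 1 (`COc1cc(-c2nnc(SCc3ccccc3Cl)n2N2C(=O)c3ccccc3C2=O)cc(OC)c1OC`), with a 2-chlorophenyl group in that place, also sits at a limit, giving > 200000 nM in this assay. Compound 2 (`COc1cc(-c2nnc(SCC(=O)c3ccc(C)cc3)n2N2C(=O)c3ccccc3C2=O)cc(OC)c1OC`), with a (4-methylphenyl)carbonyl group there, gives 6760 nM in this assay. The step of an at least 29-fold higher number from compound 2 to compound 3 (1.47 log units; beyond the scatter) shows that removing the methyl group costs a great deal, while an at least 29-fold lower number from compound 1 to compound 2 (1.47 log units; beyond the scatter) is large in the other direction and a step that the two limits leave unreadable from compound 1 to compound 3 cannot be read, as the limit of > 200000 nM in this assay, at which 2 of the 3 values shown sit, holds two of the three values.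

Compound 4 (`COc1cc(-c2nnc(SCC(=O)c3ccc(Br)cc3)n2N2C(=O)c3ccccc3C2=O)cc(OC)c1OC`) differs from compound 3 by bromo in place of hydrogen on an aromatic carbon. Going by the values given here, only one measured step concerns this position, the methyl removal from compound 2 to compound 3, and it was large. A bromo group in the same place is expected to act in the same direction, so the step of an at least 13-fold lower number from compound 3 to compound 4 (1.12 log units; beyond the scatter) is expected, though with wide uncertainty. The estimate for compound 4 in this assay is 15000 nM, within a range from 3000 nM to 200000 nM.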

Compound 4, half-maximal inhibitory concentration: 16100 nM
Beside the measured number, compound 4's estimate is 1.1-fold (0.03 log units) below it; measured number inside the range.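

With a bromo group at this place on the ring, para to a large group, the benzoyl series again comes clear of the limit, showing an at least 12-fold lower number from compound 3 to compound 4 (1.09 log units; beyond the scatter). So methyl is not the only group here that gives a readable value, although the two are not interchangeable: bromo in place of methyl gives a modest change, a 2.4-fold higher number from compound 2 to compound 4 (0.38 log units; beyond the scatter). The (4-bromophenyl)carbonyl group also stands well apart from the 2-chlorophenyl group, with an at least 12-fold lower number from compound 1 to compound 4 (1.09 log units; beyond the scatter), though the true sizes of the steps from the two limit compounds stay hidden: the limit of > 200000 nM in this assay, at which 2 of the 4 values shown sit.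

The compounds shown leave open how a fluoro group, a methoxy group or an amine would behave at this same place on the ring. They also leave open what a longer chain on the sulfur would do.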